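Replacing a chloroethyl amide with a chloropyridinyl amide

The compounds below may be only part of what the source reports. "The series", "measured", "known", "first", "only" and "open" are said of these compounds alone.

Compound 1, `O=C(O)/C=C/C(=O)Nc1cccc(-c2nc3ccccc3s2)c1`, gives 56000 nM in a physicochemical assay for solubility, in phosphate buffer, measured as kinetic solubility, with a stated time of 18 h, at pH 7.4; on this read-out higher numbers stand for higher solubility and lower numbers for lower solubility.
Compound 2, `CN(C)CCC(=O)Nc1cccc(-c2nc3ccccc3s2)c1`, gives 56000 nM in this assay.
Compound 3, `CC(Cl)C(=O)Nc1cccc(-c2nc3ccccc3s2)c1`, gives 830 nM in this assay.

Compound 3 stands lowest of the three numbers in this assay, with compound 1 and compound 2 each far above it: a 67-fold lower number from compound 1 to compound 3 (1.83 log units; beyond the scatter) and a 67-fold lower number from compound 2 to compound 3 (1.83 log units; beyond the scatter), while no change at the digits printed from compound 1 to compound 2 (within the scatter). Compound 4, `O=C(Nc1cccc(-c2nc3ccccc3s2)c1)c1cccnc1Cl`, differs from compound 3 by 2-chloropyridin-3-yl in place of 1-chloroethyl on a carbonyl carbon. Going by the values given here, none of the measured steps exchanges one uncharged group for another, so they give no direct guide; both large steps removed an ionisable group, which compound 3 and compound 4 alike lack. For compound 4 a step of a 1.7-fold lower number from compound 3 to compound 4 (0.22 log units; within the scatter) in this assay is therefore expected, no larger than the scatter. Compound 4 is estimated at 500 nM, within 100 nM to 3000 nM.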

Compound 4, solubility: 520 nM
Compound 4: middle estimate off by 1.0-fold (0.02 log units), on the low side; low and high end bracket the measured number.
By their numbers in this assay, from the lowest: compounds 4 and 3 (each within the scatter of the next); then compounds 1 and 2 (each within the scatter of the next).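

With a 1.6-fold lower number from compound 3 to compound 4 (0.20 log units; within the scatter) in this assay, the exchange of 1-chloroethyl for 2-chloropyridin-3-yl on the carbonyl carbon, which brings in a six-membered aromatic ring and a hydrogen-bond acceptor, leaves compound 4 level with compound 3. Going by these compounds alone, the large gap to the earlier compounds thus also appears with a ring at this position, with a 110-fold lower number from compound 2 to compound 4 (2.03 log units; beyond the scatter) and a 110-fold lower number from compound 1 to compound 4 (2.03 log units; beyond the scatter) in this assay for those exchanges. Going by these compounds, whether a pyridin-3-yl without its chlorine or a hydroxyethyl group would stay with compound 3 and compound 4 or come nearer to compound 1 and compound 2 remains open. Nothing given here accounts for any of these steps.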